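Removing a Phenyl Ring and Cytotoxicity in Rat Cells

This account rests on a few compounds, and the source may have more. Where it says the series, first, only, none or still open, it means among the compounds named here.

Four compounds share a related core and differ mainly in the chain attached to an amine nitrogen. In an ADME assay on L6 cells (Rattus norvegicus) for cytotoxicity (a higher number here means a weaker inhibitor, a lower number a stronger inhibitor), compound 1 `COc1cc2c(cc1C(C)N[C@H](C)c1ccccc1)C=CC(C)(C)O2` gives 15900 nM. Compound 2 `CCNC(C)c1cc2c(cc1OC)OC(C)(C)C=C2` differs from compound 1 in one place: hydrogen in place of phenyl on a saturated chain carbon bound to an amine nitrogen and a saturated chain carbon. This change gave an 11-fold higher number from compound 1 to compound 2 (1.04 log units; beyond the scatter), and in this assay compound 2 gives 176000 nM, so removing the phenyl made a weaker inhibitor of cell growth. Compound 3 `COc1cc2c(cc1C(C)NCCCCc1ccccc1)CCC(C)(C)O2` has the lowest number of the three; in this assay compound 3 gives 5280 nM. The difference between the core of compound 3 and the core of compound 1 is not broken down here.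

Compound 4 `CCCCNC(C)c1cc2c(cc1OC)OC(C)(C)CC2` has not yet been measured. It differs from compound 3 in one place: hydrogen in place of phenyl on a saturated chain carbon, four bonds along the chain from an amine nitrogen. This is the same kind of change as that from compound 1 to compound 2, but the place is not the same: in compound 1 the phenyl sits on a saturated chain carbon bound to an amine nitrogen and a saturated chain carbon, whereas in compound 3 it sits on a saturated chain carbon, four bonds along the chain from an amine nitrogen. The same direction is expected here because the earlier step was an 11-fold higher number from compound 1 to compound 2 (1.04 log units; beyond the scatter). Since the place differs, a somewhat smaller step is expected, a 6.1-fold higher number from compound 3 to compound 4 (0.78 log units; beyond the scatter). Compound 4 is therefore expected to give about 32000 nM in this assay, most likely between 12000 nM and 90000 nM.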

Compound 4, half-maximal inhibitory concentration: 59000 nM
For compound 4 the middle estimate is 1.8-fold (0.27 log units) below the measured one; the measured number falls inside the stated range.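

Replacing phenyl with hydrogen on a saturated chain carbon, four bonds along the chain from an amine nitrogen, gave an 11-fold higher number from compound 3 to compound 4 (1.05 log units; beyond the scatter) in this assay, meaning that more compound was needed for the same effect on the cells. Set beside the earlier removal of a phenyl, this step shows that the change carried over from one core to the other with no measurable difference in size: the same change on two cores in this assay, an 11-fold higher number (1.04 log units; beyond the scatter) from compound 1 to compound 2 and an 11-fold higher number (1.05 log units; beyond the scatter) from compound 3 to compound 4, 1.0-fold (0.00 log units) apart, within the scatter of two such steps This rests on only two pairs in a single test on rat cells, and the phenyl sits at a different place on the chain in each pair, so it shows agreement for these two cores and does not show that the same step would appear on any other core, nor why the phenyl matters.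

Still open, as far as these compounds go, is how a cyclohexyl or pyridyl ring in place of the phenyl would read in this assay, and whether a phenethyl or 3-phenylpropyl group on the amine nitrogen would fall between the values with and without the phenyl. Also open, from the compounds shown here alone, is whether the step would keep its size on a core carrying a hydroxyl group instead of the methoxy group.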